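Urea partner swap: dichlorophenyl to trifluoromethylphenyl

The source may hold more compounds than are shown below. What is called first, only, known or untested is meant among the compounds shown, and "the series" means these compounds.

Compound 1, `COc1cc(-c2nn(-c3cccc(NC(=O)Nc4cc(C(F)(F)F)cc(C(F)(F)F)c4)c3)cc2-c2ccncc2)ccc1Cl`: 2730 nM
Compound 2, `COc1cc(-c2nn(-c3cccc(NC(=O)c4cccc(C(F)(F)F)c4)c3)cc2-c2ccncc2)ccc1Cl`: > 50000 nM (a limit of the assay)
Compound 3, `COc1cc(-c2nn(-c3cccc(NC(=O)Nc4ccc(Cl)c(Cl)c4)c3)cc2-c2ccncc2)ccc1Cl`: > 50000 nM (a limit of the assay)

In a functional assay on UO-31 cells (Homo sapiens) for inhibition, read by sulforhodamine B assay, with a stated time of 48 h (a lower number here means that less compound is tolerated, a higher number that more compound is tolerated), compound 1 gives 2730 nM. For compound 2 the assay reports only a limit, > 50000 nM. For compound 3 likewise only a limit is reported, > 50000 nM. Compound 3 therefore stands at the edge of what this assay can read, and the step that the two limits leave unreadable from compound 2 to compound 3 cannot be sized because of the limit of > 50000 nM in this assay, at which 2 of the 3 values shown sit.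

Compound 4, `COc1cc(-c2nn(-c3cccc(NC(=O)Nc4cccc(C(F)(F)F)c4)c3)cc2-c2ccncc2)ccc1Cl`, differs from compound 3 in one place: 3-(trifluoromethyl)phenyl in place of 3,4-dichlorophenyl on an amide-type nitrogen. For the measured compounds named here, no measured step covers exactly this change. The nearest guide is compound 1, which carries two trifluoromethyl groups on the same urea partner and gives a readable number, while compound 3 with the dichlorophenyl partner gives only a limit.

Compound 4 is expected to land at about 20000 nM, within roughly 5000 nM to 60000 nM. Going by these compounds, the step of an at least 2.5-fold lower number from compound 3 to compound 4 (0.39 log units; beyond the scatter) is thus expected to move toward less compound tolerated, though from a limit its true size is unknown, and a second limit would not be surprising.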

Compound 4, concentration lethal to 50% of the cells: > 50000 nM
Compound 4: a limit, no number; the forecaster's own chance of this, stated with the estimate: 40%; at least 2.5-fold (0.39 log units) between middle value and limit.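

In this assay compound 4 gives only a limit, > 50000 nM, so a single trifluoromethyl group on the urea partner does not bring the result into the readable range. For the compounds shown here, the one readable step is an at least 18-fold higher number from compound 1 to compound 4 (1.26 log units; beyond the scatter): with hydrogen in place of one trifluoromethyl group, the readable number of compound 1 is lost, so the second trifluoromethyl group matters. The steps among compound 2, compound 3 and compound 4 cannot be read, so no order can be given for these three: the limit of > 50000 nM in this assay, at which 3 of the 4 values shown sit.

Going by these compounds, how far compound 2, compound 3 and compound 4 really lie past that limit remains unknown. On these data alone, it also remains open whether a nitrile or a carboxylic acid in place of the remaining trifluoromethyl group on the urea partner would give a readable number.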